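A Chloro Group Enters the Ring of Compound 3

A few compounds are considered here, and "the series" means these few. Any claim that something is new, unique, unknown or untested is made for them only; others in the source may bear on it.

Of the compounds shown here, three sharing one core have been tested in a functional assay on EA.hy 926 cells (Homo sapiens) for cytotoxicity, read by MTT assay, with stated times of 24 h and 12 h, tested at 100 uM; a lower number here means a weaker effect, a higher number a stronger effect of the compound at the concentration tested. Compound 1 `CCOC(=O)/C=C/c1cc(OC)ccc1OC(=O)c1nc(C)c(C)nc1C` gives 46.2%. Compound 2 `Cc1nc(C)c(C(=O)Oc2ccc(Cl)cc2/C=C/C(=O)O)nc1C` gives 52.2%. Compound 3 `CCOC(=O)/C=C/c1ccccc1OC(=O)c1nc(C)c(C)nc1C` gives 40.9%, the lowest of the three numbers; its gap to compound 1 lies within the scatter, while compound 2 stands beyond the scatter above it.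

The next compound, compound 4 `CCOC(=O)/C=C/c1cc(Cl)ccc1OC(=O)c1nc(C)c(C)nc1C`, differs from compound 3 in one place: chloro in place of hydrogen on an aromatic carbon. Among the compounds with values here, one measured step touches the same position, where the change was a number 5.3 percentage points lower from compound 1 to compound 3 (within the scatter). Compound 2 also carries a chloro group on this ring but differs from compound 4 elsewhere as well, so only its value and that of compound 3 can be set side by side, and their gap lies beyond the scatter.

Since replacing methoxy by hydrogen left the number within the scatter, the chloro group is expected to move it little, and the step from compound 3 to compound 4 is estimated as a number 4.1 percentage points higher from compound 3 to compound 4 (within the scatter). Compound 4 is thus expected to give about 45%, somewhere between 34% and 57%.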

Compound 4, a percentage reported as activity, at one concentration (the size of the read-out at that concentration, not a potency): 11%
Beside the measured number, compound 4's estimate is 34 percentage points above it; measured number below the stated range.
By their numbers in this assay, from the lowest: compound 4; then compounds 3, 1 and 2 (each within the scatter of the next, the first and the last beyond it).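

In this assay, this ring position, para to a large group, proves far from indifferent: methoxy and hydrogen there stay within the scatter of each other, yet chloro brings a number 29.9 percentage points lower from compound 3 to compound 4 (beyond the scatter) and also a number 35.2 percentage points lower from compound 1 to compound 4 (beyond the scatter) in a single exchange. So the group placed here can matter greatly, and the small earlier step did not reveal this. Chloro on this ring does not give a low number on its own, since adding ethyl to the acid oxygen of compound 2 produces a number 41.2 percentage points lower from compound 2 to compound 4 (beyond the scatter) while the chloro group stays in place.

No measurement shown here accounts for these drops. On these data alone, whether fluoro, bromo or trifluoromethyl at this position would behave like chloro remains open, as does the effect of a methyl or longer chain in place of the ethyl group.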